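This account rests on a few compounds, and the source may have more. Where it says the series, first, only, none or still open, it means among the compounds named here.

Two compounds carry the measurement so far. Compound 1 `CC(Oc1ccc(-c2ccccc2)cc1)C(=O)Cn1nnc(-c2ccc(Cl)cc2)n1` gives 6.1 in a physicochemical assay for lipophilicity, read by HPLC, tested at 5 mM; a higher number here means a more lipophilic compound, a lower number a more polar compound. Compound 2 `COC(=O)c1ccc(-c2nnn(CC(=O)C(C)Oc3ccc(Oc4ccc(C(F)(F)F)cc4)cc3)n2)cc1` gives 6.2 in this assay, and the two values lie within the scatter of each other, so no order between them can be read. Compound 3 `COC(=O)c1ccc(-c2nnn(CC(=O)C(C)Oc3ccc(-c4ccccc4)cc3)n2)cc1` is not yet measured; it differs from compound 2 by phenyl in place of 4-(trifluoromethyl)phenoxy on an aromatic carbon. Among the compounds with values here, no measured pair shows this change. A drop beyond the scatter is expected, a number 0.60 log units lower from compound 2 to compound 3 (beyond the scatter), since compound 1, which also carries the phenyl, gives 6.1. Compound 3 is thus estimated at 5.6, between 5.1 and 6.1.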

Compound 3, partition coefficient: 5.4
The estimate for compound 3 lay 0.20 log units above the measured number; low and high end bracket the measured number.
By their numbers in this assay, from the lowest: compound 3; then compounds 1 and 2 (each within the scatter of the next).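

In this assay, within the data shown here, phenyl in place of 4-(trifluoromethyl)phenoxy on an aromatic carbon gives a number 0.80 log units lower from compound 2 to compound 3 (beyond the scatter) as the first measured step at this position. Methoxycarbonyl in place of chloro on an aromatic carbon gives a number 0.70 log units lower from compound 1 to compound 3 (beyond the scatter) in a second place, so each of these two single changes moves the number beyond the scatter. The compounds shown leave open where plain phenoxy would fall at the first position and where a carboxylic acid would fall in place of the methoxycarbonyl. No measurement at hand accounts for either step.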